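The compounds below may be only part of what the source reports. "The series", "measured", "known", "first", "only" and "open" are said of these compounds alone.

Measured compounds:
- Compound 1, `COc1ccc(C(=O)NO)cc1C(=O)Nc1ccc2c(c1)cc(C)c(=O)n2C`, gives 65 nM in an assay on isolated protein for inhibition of histone deacetylase 8 (Homo sapiens), read by fluorescence, with a stated time of 90 min; on this read-out lower numbers stand for stronger inhibition and higher numbers for weaker inhibition.
- Compound 2, `COc1ccc(C(=O)NO)cc1CS(=O)(=O)Nc1ccc2c(c1)cc(C)c(=O)n2C`, gives 158 nM in this assay.

Compound 1 has the lowest number of the two; compound 2, its nearest neighbour, sits beyond the scatter above it. Compound 3, `Cc1cc2cc(NC(=O)c3cc(C(=O)NO)ccc3Cl)ccc2n(C)c1=O`, is not yet measured. It differs from compound 1 by chloro in place of methoxy on an aromatic carbon. For the measured compounds named here, no step of this kind has been measured here, so the expectation rests on compound 1 alone. The step from compound 1 to compound 3 is expected to be small, a 1.2-fold higher number from compound 1 to compound 3 (0.09 log units; within the scatter), within or just at the edge of the scatter. Compound 3 is therefore estimated at 80 nM, between 30 nM and 220 nM.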

Compound 3, half-maximal inhibitory concentration: 113 nM
Compound 3: middle estimate off by 1.4-fold (0.15 log units), on the low side; the measured number falls inside the stated range.
By their numbers in this assay, from the lowest: compounds 1, 3 and 2 (each within the scatter of the next, the first and the last beyond it).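

Replacing methoxy with chloro on this aromatic carbon, ortho to a large group and para to a hydroxycarbamoyl group, gives a 1.7-fold higher number from compound 1 to compound 3 (0.24 log units; within the scatter) in this assay. The two compounds therefore cannot be told apart in this assay, even though methoxy's oxygen, a hydrogen-bond acceptor, is gone and a single chlorine atom stands in its place. No measurement is available that would explain this result. On these data alone, whether an amine, a hydroxyl group or a longer chain such as ethoxy on this carbon would give a similar number remains open. So does whether this swap would behave the same way in compound 2.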